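A few compounds are considered here, and "the series" means these few. Any claim that something is new, unique, unknown or untested is made for them only; others in the source may bear on it.

Two analogues built on one shared core have been measured in a functional assay on B16-F10 cells (Mus musculus) for inhibition, read by MTT assay, with a stated time of 72 h; a lower number here means a stronger inhibitor, a higher number a weaker inhibitor. Compound 1 `CC(C)c1ccc(-c2nc(SCc3cn(CC(=O)NC(=O)Nc4ccccn4)nn3)nc(Nc3ccccc3Cl)c2C#N)cc1` gives 6790 nM there. Compound 2 `CC(C)c1ccc(-c2nc(SCc3cn(CC(=O)NC(=O)Nc4ccccn4)nn3)nc(Nc3ccc(F)cc3)c2C#N)cc1` gives 7250 nM in this assay. Among the measured compounds shown here, the only step between them, a 1.1-fold higher number from compound 1 to compound 2 (0.03 log units; within the scatter), stays within the scatter, so compound 2 stands level with compound 1 rather than apart from it. Compound 3 `CC(C)c1ccc(-c2nc(SCc3cn(CC(=O)NC(=O)Nc4ccccn4)nn3)nc(Nc3ccc(Cl)cc3)c2C#N)cc1` is compound 2 with chloro in place of fluoro on an aromatic carbon. For the measured compounds named here, no measured step makes this same swap; the one step seen, exchanging the ring on that nitrogen, barely moved the number, so only a small shift is expected. Compound 3 is estimated at 6500 nM, within 3000 nM to 14000 nM. That expectation amounts to a 1.1-fold lower number from compound 2 to compound 3 (0.05 log units; within the scatter).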

Compound 3, half-maximal inhibitory concentration: 860 nM
Beside the measured number, compound 3's estimate is 7.6-fold (0.88 log units) above it; the measured number lies below the stated range.
By their numbers in this assay, from the lowest: compound 3; then compounds 1 and 2 (each within the scatter of the next).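

In this assay, the ring on that nitrogen proves sensitive after all: chloro in place of fluoro on an aromatic carbon, para to a large group, brings a clear gain (an 8.4-fold lower number from compound 2 to compound 3 (0.93 log units; beyond the scatter)). The position of the chlorine counts too, as 4-chlorophenyl in place of 2-chlorophenyl also brings a gain (a 7.9-fold lower number from compound 1 to compound 3 (0.90 log units; beyond the scatter)), something the level pair of compound 1 and compound 2 could not reveal. Nothing available explains this difference. The compounds shown leave open how bromo, methyl or methoxy would fare on that same carbon.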